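Solubility notes on compound 2 and its methyl analogue

The source may hold more compounds than are shown below. What is called first, only, known or untested is meant among the compounds shown, and "the series" means these compounds.

Measured compounds:
compound 1 `CN1C(=O)C2=C(C1=O)N(CC(=O)Nc1ccc(-c3ccccc3)cn1)CCC2`: 0.24 ug/mL
compound 2 `CN1C(=O)C2=C(C1=O)N(CC(=O)Nc1ccc(-c3cccnc3)nn1)CCC2`: 9.5 ug/mL
compound 3 `CN1C(=O)C2=C(C1=O)N(CC(=O)Nc1ccc(-c3ccccc3)nc1)CCC2`: 0.75 ug/mL

In a physicochemical assay for solubility, measured as thermodynamic solubility, at pH 7.4 (a higher number here means a more soluble compound, a lower number a less soluble compound), compound 2 gives the highest of the three numbers. Compound 3 lies beyond the scatter below it, and compound 1 further below still. All three share the same core and differ only in the two aromatic rings at the amide end; no two of them differ in a single place, so the gaps between them are read simply as what the numbers show, without a single change to assign them to.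

Compound 4 `Cc1ccc(-c2ccc(NC(=O)CN3CCCC4=C3C(=O)N(C)C4=O)nn2)cn1` is not yet measured. It differs from compound 2 in one place:
methyl in place of hydrogen on an aromatic carbon
The same difference, taken one bond further out, reads pyridin-3-yl to 6-methylpyridin-3-yl. For the measured compounds named here, no measured pair carries this change, so the expectation rests on compound 2 alone, whose value in this assay is 9.5 ug/mL. A step of modest size downward from compound 2 to compound 4, a 1.9-fold lower number from compound 2 to compound 4 (0.28 log units; within the scatter), is expected, with a fair chance that it stays within the scatter. Compound 4 is estimated at 5 ug/mL, with a range from 1.5 ug/mL to 15 ug/mL.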

Compound 4, solubility: 35.5 ug/mL
Compound 4: middle estimate off by 7.1-fold (0.85 log units), on the low side; measured number outside the range, above it.
By their numbers in this assay, from the lowest: compound 1; then compound 3; then compound 2; then compound 4.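

The series now holds its first pair differing in one place, and in this assay the gap can be set against a single change: methyl in place of hydrogen on an aromatic carbon, next to the ring nitrogen and para to a large group, goes with a 3.7-fold higher number from compound 2 to compound 4 (0.57 log units; beyond the scatter) on the pyridin-3-yl ring. The step is upward and beyond the usual scatter, so at this position the higher number sits with the 6-methylpyridin-3-yl compound, even though the methyl adds one carbon and no hydrogen-bond donors or acceptors. No measurement at hand bears on what lies behind the step, which stands as an observation on this one pair.

Going by these compounds, one pair sets no pattern, and whether methyl on the outer six-membered aromatic ring of compound 1 or compound 3 goes with a step in the same direction stays open. Also open, on these data alone, is how the number in this assay moves with a longer chain such as ethyl, or with an amine or a carboxylic acid, on the same aromatic carbon.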